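Tert-Butyl for Propyl on the Amide Nitrogen

The source may report more compounds than this note shows. Statements on the series, on what has been measured and on what is new or still open speak of the compounds shown alone.

Compound 1 `C=CC1=C(C(=O)NCCC)C(c2ccc(Cl)c(Cl)c2)OC1` was tested in a functional assay on SW480 cells (Homo sapiens) for cytotoxicity, read by MTT assay, with a stated time of 24 h; on this read-out higher numbers stand for weaker inhibition and lower numbers for stronger inhibition. In this assay compound 1 gives > 100000 nM, which is a limit of the assay rather than a number. Compound 2 `C=CC1=C(C(=O)NCc2ccc(Cl)cc2)C(c2ccc(F)cc2)OC1` gives > 100000 nM, also a limit. Compound 3 `C=CC1=C(C(=O)NCc2ccccc2F)C(c2ccc(F)cc2)OC1` gives > 100000 nM, again a limit. The step that the two limits leave unreadable from compound 2 to compound 3 is therefore not readable. Compound 4 `C=CC1=C(C(=O)NC(C)(C)C)C(c2ccc(Cl)c(Cl)c2)OC1` differs from compound 1 by tert-butyl in place of propyl on an amide-type nitrogen. Within the data shown here, no measured step bears directly on this change, and because every value shown sits at the limit of > 100000 nM in this assay, at which 3 of the 3 values shown sit, there is no measured size to carry over. The expected step for compound 4 is a step that the limit leaves unreadable from compound 1 to compound 4, with a limit the most likely outcome again. Compound 4 is estimated at 150000 nM, within 50000 nM to 500000 nM.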

Compound 4, half-maximal inhibitory concentration: > 100000 nM
Compound 4 was reported as a limit (the forecaster's own chance of this, stated with the estimate: 85%); the middle value is on the limit's open side.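

Among these compounds, compound 1 and compound 4 each give only a limit rather than a number, so no step between them can be read. On these data alone, how tert-butyl and propyl compare in this assay stays open.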